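The compounds below may be only part of what the source reports. "The series", "measured", "known", "first", "only" and "open" are said of these compounds alone.

Measured so far in an ADME assay on HepG2 2.2.15 cells (Homo sapiens) for cytotoxicity, read by MTT assay; on this read-out lower numbers stand for higher toxicity in this test and higher numbers for lower toxicity in this test:
- compound 1 `CC(=O)c1ccc(OC(=O)c2cccnc2)cc1`: 3010000 nM
- compound 2 `CC(=O)c1ccc(OC(=O)c2ccco2)cc1`: > 4040000 nM
- compound 3 `CC(=O)c1ccc(O[C@@H]2O[C@H](COC(=O)c3cccnc3)[C@@H](O)[C@H](O)[C@H]2O)cc1`: > 1650000 nM

Compound 2 sits at the limit of this assay, so its value is a limit and not a number. Compound 3 likewise sits at a limit of this assay. For the measured compounds named here, the one measured step is an at least 1.3-fold higher number from compound 1 to compound 2 (0.12 log units; that floor lies within the scatter), made by furan-2-yl in place of pyridin-3-yl on a carbonyl carbon; it is open-ended because compound 2 sits at the limit of > 4040000 nM in this assay, at which 1 of the 3 values shown sits.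

The cores of compound 1 and compound 3 differ in more than one place, and that difference is not broken down here.

Compound 4 `CC(=O)c1ccc(O[C@@H]2O[C@H](COC(=O)c3ccco3)[C@@H](O)[C@H](O)[C@H]2O)cc1` has not been measured. It differs from compound 3 by furan-2-yl in place of pyridin-3-yl on a carbonyl carbon, the same change as from compound 1 to compound 2, at the same place. For compound 4 the expected step is a step that the limit leaves unreadable from compound 3 to compound 4, resting on the step of an at least 1.3-fold higher number from compound 1 to compound 2 (0.12 log units; that floor lies within the scatter) and on compound 3 already standing at the limit of > 1650000 nM in this assay, at which 1 of the 3 values shown sits. Compound 4 is estimated at 3000000 nM, most likely again reported as a limit, with an expected range from 1200000 nM to 8000000 nM.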

Compound 4, half-maximal cytotoxic concentration: 1170000 nM
Compound 4: the middle estimate sits 2.6-fold (0.41 log units) above what was measured, outside the stated range (below it).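

In this assay, carrying furan-2-yl in place of pyridin-3-yl on a carbonyl carbon over to the core of compound 3 gives an at least 1.4-fold lower number from compound 3 to compound 4 (0.14 log units; that floor lies within the scatter). Compound 3 stands at > 1650000 nM, which is a limit of the assay and not a number. The two cores therefore show neither that this change carries over as one step nor that its outcome depends on the core: the same change on two cores in this assay, an at least 1.3-fold higher number (0.12 log units; that floor lies within the scatter) from compound 1 to compound 2 and an at least 1.4-fold lower number (0.14 log units; that floor lies within the scatter) from compound 3 to compound 4; the limit leaves it open whether they differ

Going by these compounds, the true size of the step on either core stays open, since compound 2 and compound 3 both stand at limits. Also open, on these data alone, is how a plain phenyl group, an amine-bearing ring or a longer alkyl chain on the same carbonyl carbon would read in this assay on either core.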